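Aryl substituent variation on the acylguanidine benzamide core

A few compounds are considered here, and "the series" means these few. Any claim that something is new, unique, unknown or untested is made for them only; others in the source may bear on it.

Compounds measured in a functional assay for inhibition of sodium/hydrogen exchanger (Oryctolagus cuniculus); on this read-out lower numbers stand for stronger inhibition and higher numbers for weaker inhibition:
compound 1 `Cc1cc(C)c(S(C)(=O)=O)cc1C(=O)N=C(N)N` gives 11 nM
compound 2 `Cc1cc(-c2ccc(Cl)cc2Cl)c(S(C)(=O)=O)cc1C(=O)N=C(N)N` gives 42 nM
compound 3 `Cc1cc(OC(C)(C)C)c(S(C)(=O)=O)cc1C(=O)N=C(N)N` gives 9.4 nM

Compound 3 shows the lowest number of the three, but its gap to compound 1 lies within the scatter, so the two cannot be ranked; only compound 2 stands apart, a 4.5-fold lower number from compound 2 to compound 3 (0.65 log units; beyond the scatter). Compound 4 `Cc1cc(C(F)(F)F)c(S(C)(=O)=O)cc1C(=O)N=C(N)N` differs from compound 3 by trifluoromethyl in place of tert-butoxy on an aromatic carbon. For the measured compounds named here, the steps that bear on this are a 1.2-fold lower number from compound 1 to compound 3 (0.07 log units; within the scatter), a change within the scatter, and a 3.8-fold higher number from compound 1 to compound 2 (0.58 log units; beyond the scatter), a modest rise. Trifluoromethyl, like methyl and tert-butoxy, carries no ring, unlike the dichlorophenyl of compound 2, so no step beyond the scatter is expected, a 1.3-fold higher number from compound 3 to compound 4 (0.11 log units; within the scatter). Compound 4 is estimated at 12 nM, range 5 nM to 30 nM.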

Compound 4, half-maximal inhibitory concentration: 37 nM
Compound 4: the middle estimate sits 3.1-fold (0.49 log units) below what was measured, and the stated range ends below it.
By their numbers in this assay, from the lowest: compounds 3 and 1 (each within the scatter of the next); then compounds 4 and 2 (each within the scatter of the next).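

Having no ring does not keep a group at this position on the low side in this assay: trifluoromethyl gives a 3.9-fold higher number from compound 3 to compound 4 (0.60 log units; beyond the scatter) and a 3.4-fold higher number from compound 1 to compound 4 (0.53 log units; beyond the scatter) in this series, while a 1.1-fold lower number from compound 2 to compound 4 (0.06 log units; within the scatter) leaves it level with 2,4-dichlorophenyl. Heavy-atom count does not sort the position either, as tert-butoxy and methyl, with more and fewer heavy atoms than trifluoromethyl, stay together on the low side. Nothing on hand accounts for this rise.

From the compounds shown here alone, it remains open whether methoxy or an amine at this position would group with compound 1 and compound 3 or with compound 2 and compound 4. A nitrile or a chlorine atom would test the same question.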